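Carbonyl to carbamoyl on the dichlorophenyl arm

This account rests on a few compounds, and the source may have more. Where it says the series, first, only, none or still open, it means among the compounds named here.

Working notes on the series. Two members of the set have been run so far, both on the same core and differing only at the amide end. In a functional assay on LOX IMVI cells (Homo sapiens) for inhibition, read by sulforhodamine B assay, with a stated time of 48 h, tested at 10 uM (on this read-out lower numbers stand for a stronger effect and higher numbers for a weaker effect at the one concentration tested), compound 1 `COc1cc(Cl)cc(-c2nn(-c3cccc(NC(=O)c4cc(C(F)(F)F)cc(C(F)(F)F)c4)c3)cc2-c2ccncc2)c1` gives 76.1%. In this assay compound 2 `COc1cc(Cl)cc(-c2nn(-c3cccc(NC(=O)c4ccc(Cl)c(Cl)c4)c3)cc2-c2ccncc2)c1` gives 72.8%. Compound 2 carries the lowest of the two numbers, but compound 1, the nearest, sits within the scatter of it, so no order between the two is claimed.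

Compound 3 `COc1cc(Cl)cc(-c2nn(-c3cccc(NC(=O)Nc4ccc(Cl)c(Cl)c4)c3)cc2-c2ccncc2)c1` is the next candidate. It differs from compound 2 by (3,4-dichlorophenyl)amino in place of 3,4-dichlorophenyl on a carbonyl carbon, which read one bond further out is (3,4-dichlorophenyl)carbonyl to (3,4-dichlorophenyl)carbamoyl. Among the measured compounds shown here, no step between measured compounds covers such a change, so no size can be taken from the data. For compound 3 the expected step is a number 2.8 percentage points lower from compound 2 to compound 3 (within the scatter), essentially none beyond the scatter. Compound 3 is therefore estimated at 70%, between 50% and 90%.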

Compound 3, a percentage reported as activity, at one concentration (the size of the read-out at that concentration, not a potency): 9.24%
Compound 3: middle estimate off by 60.8 percentage points, on the high side, outside the stated range (below it).
By their numbers in this assay, from the lowest: compound 3; then compounds 2 and 1 (each within the scatter of the next).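

In this assay the link on the dichlorophenyl arm proves far more sensitive than the two amides suggested: (3,4-dichlorophenyl)amino in place of 3,4-dichlorophenyl on a carbonyl carbon gives a number 63.6 percentage points lower from compound 2 to compound 3 (beyond the scatter), whereas compound 1 and compound 2 lie within the scatter of each other. The aromatic ring and both chlorines are kept, so this large step goes with the entering nitrogen and its hydrogen-bond donor, not with any change on the ring. Nothing available bears on the reason for the step.

The compounds shown leave open whether the same change gives a step of this size on the trifluoromethyl-bearing arm of compound 1. They also leave open how the link behaves with a methyl group on the entering nitrogen, or with an oxygen atom or a methylene group in that nitrogen's place.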